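Vero cytotoxicity in the fused bicyclic series: compound 4

The source may report more compounds than this note shows. Statements on the series, on what has been measured and on what is new or still open speak of the compounds shown alone.

Among the compounds with values here, the three measured members share one core and differ only in the aryl group at one position. Compound 1 `c1cc(NC2CCCC2)c2nc(-c3ccc(OCC4CC4)cc3)c(-c3ccnc(NC4CCCC4)n3)n2c1` carries a 4-(cyclopropylmethoxy)phenyl. In an ADME assay on Vero cells (Chlorocebus sabaeus) for cytotoxicity (on this read-out higher numbers stand for lower toxicity in this test and lower numbers for higher toxicity in this test), compound 1 reaches only the assay limit, > 40000 nM. Compound 2 `C=CCOc1cccc(-c2nc3c(NC4CCCC4)cccn3c2-c2ccnc(NC3CCCC3)n2)c1` carries a 3-(allyloxy)phenyl. In this assay compound 2 likewise reaches only the limit, > 40000 nM. Compound 3 `N#Cc1cccc(-c2nc3c(NC4CCCC4)cccn3c2-c2ccnc(NC3CCCC3)n2)c1` carries a 3-cyanophenyl. In this assay compound 3 again gives only the limit, > 40000 nM. Because all three values sit at the limit of > 40000 nM in this assay, at which 3 of the 3 values shown sit, none of the steps can be sized: a step that the two limits leave unreadable from compound 1 to compound 2, a step that the two limits leave unreadable from compound 1 to compound 3 and a step that the two limits leave unreadable from compound 2 to compound 3 all stay unreadable. Compound 3 thus stands at the limit, together with the two others.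

Compound 4 `Cc1ccc(-c2nc3c(NC4CCCC4)cccn3c2-c2ccnc(NC3CCCC3)n2)cc1` differs from compound 3 by 4-methylphenyl in place of 3-cyanophenyl on an aromatic carbon. Within the data shown here, the measured steps bearing on this change are the three unreadable ones just named; they show only that three different aryl groups at this position, including a 3-cyanophenyl, all leave the read-out at the limit. The step from compound 3 to compound 4 is therefore expected to be a step that the limit leaves unreadable from compound 3 to compound 4, that is, no readable step. Compound 4 is estimated at 60000 nM, within 30000 nM to 150000 nM, most likely reported again as a limit.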

Compound 4, half-maximal cytotoxic concentration: > 40000 nM
Compound 4: a limit, no number; the forecaster's own chance of this, stated with the estimate: 85%; the middle value does not contradict the limit.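

In this assay compound 4 gives > 40000 nM, a limit and not a number. No step from compound 1, compound 2 or compound 3 to compound 4 can be read, because all four compounds share the same result: the limit of > 40000 nM in this assay, at which 4 of the 4 values shown sit.

The compounds shown leave open how far these aryl groups differ in cytotoxicity, since none gives a number.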